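This account rests on a few compounds, and the source may have more. Where it says the series, first, only, none or still open, it means among the compounds named here.

Of the compounds shown here, three built on a shared core have been measured in a functional assay on HeLa cells (Homo sapiens) for inhibition, read by cell counting, with a stated time of 4 days; on this read-out lower numbers stand for stronger inhibition and higher numbers for weaker inhibition. Compound 1 `COc1cccc(-c2nn3cc(-c4cccc(N)c4)nc3s2)c1` gives 230000 nM in this assay. Compound 2 `CCc1ccc(-c2nn3cc(-c4cccc(N)c4)nc3s2)cc1` gives 8100 nM in this assay. Compound 3 `C=C(Br)C(=O)Nc1cccc(-c2cn3nc(-c4ccc(F)cc4)sc3n2)c1` gives 870 nM in this assay. Among these three numbers compound 2 stands second highest: the nearest to it is compound 3, whose number is lower by a margin beyond the usual scatter, and the furthest is compound 1, whose number is higher, again beyond the scatter.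

Compound 4 `Nc1cccc(-c2cn3nc(-c4ccc(Cl)cc4)sc3n2)c1` has not yet been measured. It differs from compound 2 in a single place: chloro in place of ethyl on an aromatic carbon. Among the measured compounds shown here, no two measured compounds differ from each other in only this one place, so there is no measured step of this kind to lean on, and the other two measured compounds each differ from compound 2 in more than one place. The change itself is modest, swapping one small substituent for another on the same ring carbon. For that reason the expected step in this assay is small, a 1.4-fold lower number from compound 2 to compound 4 (0.13 log units; within the scatter), in either direction and not beyond the scatter. Compound 4 is therefore expected to give about 6000 nM in this assay, most likely between 2000 nM and 20000 nM.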

Compound 4, half-maximal inhibitory concentration: 160000 nM
The estimate for compound 4 lay 27-fold (1.43 log units) below the measured number; the measured number lies above the stated range.
By their numbers in this assay, from the lowest: compound 3; then compound 2; then compounds 4 and 1 (each within the scatter of the next).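

In this assay, the change of chloro in place of ethyl on an aromatic carbon, para to a large group, gives a 20-fold higher number from compound 2 to compound 4 (1.30 log units; beyond the scatter) and so marks a large loss of inhibition. Among the compounds shown here, this is the first step that can be read at this position, and it shows that the position is far from indifferent to what it carries: the two groups are both small, with ethyl at 2 heavy atoms and chloro at 1, and neither has a hydrogen-bond donor, a hydrogen-bond acceptor or a net charge, yet the outcome differs well beyond the scatter. No measurement shown here accounts for the size of this step.

From the compounds shown here alone, with a single pair, it stays open whether ethyl helps inhibition at this carbon or chloro harms it, and a methyl group, a longer chain such as propyl or an amine at the same place could help separate the two. Going by these compounds, it is also open whether the same swap would have a similar effect in a compound carrying a different group on the other aromatic ring, as compound 3 does.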